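The compounds below may be only part of what the source reports. "The series", "measured", "known", "first", "only" and "open" are said of these compounds alone.

Measured so far in a functional assay on PC-3 cells (Homo sapiens) for antiproliferative activity, read by MTT assay, with a stated time of 48 h; on this read-out higher numbers stand for weaker inhibition and lower numbers for stronger inhibition:
- compound 1 `COc1cc(/C=C/C(C)=O)ccc1OCc1cn(-c2c(F)cccc2F)nn1` gives 24200 nM
- compound 2 `COc1cc(/C=C/C(C)=O)ccc1OCc1cn(-c2ccccc2CO)nn1` gives 50300 nM
- compound 3 `COc1ccc(-n2cc(COc3ccc(/C=C/C(C)=O)cc3OC)nn2)cc1` gives 2010 nM

All three share one core and differ only in the aryl group on the aromatic nitrogen. Compound 3 stands lowest of the three numbers: the steps of a 12-fold lower number from compound 1 to compound 3 (1.08 log units; beyond the scatter) and a 25-fold lower number from compound 2 to compound 3 (1.40 log units; beyond the scatter) are both large, while a 2.1-fold higher number from compound 1 to compound 2 (0.32 log units; beyond the scatter) is modest. The two substituted-at-one-position aryls are thus well separated from the 4-methoxyphenyl.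

Compound 4 `COc1cc(/C=C/C(C)=O)ccc1OCc1cn(-c2ccc(-c3ccccc3)cc2)nn1` keeps that aryl position occupied but changes the substituent: phenyl in place of methoxy on an aromatic carbon. Among the measured compounds shown here, no measured step exchanges one group for another at this aromatic carbon; the measured steps all swap the whole aryl, and they show that this region moves the number a great deal, without indicating the direction for this particular exchange. The expectation is therefore a small to modest step, direction uncertain, with a slight lean toward a higher number since the one aryl without a methoxy group among the measured compounds is compound 1, and compound 1 sits well above compound 3. The estimated step is a 1.7-fold higher number from compound 3 to compound 4 (0.24 log units; within the scatter). Compound 4 is expected to give about 3500 nM, within a range of 900 nM to 14000 nM.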

Compound 4, half-maximal inhibitory concentration: 56800 nM
Estimate against measurement, compound 4: 16-fold (1.21 log units) below; measured number outside the range, above it.
By their numbers in this assay, from the lowest: compound 3; then compound 1; then compounds 2 and 4 (each within the scatter of the next).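

In this assay, phenyl in place of methoxy on an aromatic carbon, para to a large group, is a large step (a 28-fold higher number from compound 3 to compound 4 (1.45 log units; beyond the scatter)), and it is the only step shown that keeps the aryl on the nitrogen and changes just its substituent. Among the compounds shown here, this position therefore responds to the substituent alone, and not only to a swap of the whole aryl: the methoxy of compound 3 is not interchangeable with a larger aromatic ring here, and the single exchange brings compound 4 within the scatter of compound 2. No measurement shown gives a reason for the size of this step.

The compounds shown leave open whether the higher number follows the added ring itself or simply the larger group, and an ethoxy, a dimethylamino or a carboxylic acid group at this carbon would help to separate the two. Also open, from the compounds shown here alone, is whether a plain hydrogen at this carbon would stand nearer to compound 3 or to compound 4.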